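Second fluoro on the six-membered aromatic ring

The source may report more compounds than this note shows. Statements on the series, on what has been measured and on what is new or still open speak of the compounds shown alone.

Compound 2 `Nc1nccn2c(Cc3cccc(F)c3)nnc12` gives only a limit, > 25 mg/kg, in a functional assay on the whole organism with Rattus norvegicus as the target, in the maximal electroshock model; a higher number here means that more compound is needed for the effect, a lower number that less compound is needed. Compound 3 `Nc1nccn2c(Cc3cc(F)ccc3F)nnc12` gives 7 mg/kg in this assay, the step being an at least 3.5-fold lower number from compound 2 to compound 3 (0.55 log units; beyond the scatter); the change is fluoro in place of hydrogen on an aromatic carbon. This step rests on the value of compound 2, which is a limit (the limit of > 25 mg/kg in this assay, at which 1 of the 3 values shown sits). Compound 1 `CNc1nccn2c(Cc3ccccc3F)nnc12` gives 5 mg/kg; the difference between the core of compound 1 and that of compound 2 is not broken down here. Compound 4 `CNc1nccn2c(Cc3c(F)cccc3F)nnc12` is unmeasured; the change from compound 1 is fluoro in place of hydrogen on an aromatic carbon. It is the same kind of change as from compound 2 to compound 3, not the same: there the entering fluoro sits para to a fluoro group, here meta to a fluoro group. A smaller step is expected, a 1.4-fold lower number from compound 1 to compound 4 (0.15 log units; within the scatter), since compound 1 already gives 5 mg/kg. Compound 4 is estimated at 3.5 mg/kg, between 1.5 mg/kg and 9 mg/kg.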

Compound 4, dose for half-maximal effect: 2 mg/kg
Compound 4: middle estimate off by 1.8-fold (0.24 log units), on the high side, within the range that was stated.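

In this assay the entering fluoro gives a 2.5-fold lower number from compound 1 to compound 4 (0.40 log units; beyond the scatter), so on the two cores shown the change runs in the same direction: the same change on two cores in this assay, an at least 3.5-fold lower number (0.55 log units; beyond the scatter) from compound 2 to compound 3 and a 2.5-fold lower number (0.40 log units; beyond the scatter) from compound 1 to compound 4; the limit leaves it open whether they differ Compound 2 gives > 25 mg/kg, which is a limit, so the size of the step on its core stays unfixed. Two pairs show a shared direction only; they give no size that can be carried to another core, and the entering fluoro does not stand in the same place relative to the first fluoro in both pairs.

The compounds shown leave open whether chloro, methoxy or trifluoromethyl at this place on the ring would follow fluoro. Also open, on these data alone, is how a longer chain in place of the methyl on the amine nitrogen of compound 4 would read.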